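The compounds below may be only part of what the source reports. "The series", "measured", "known", "first", "only" and "open" are said of these compounds alone.

Measured in a functional assay on COLO 205 cells (Homo sapiens) for cytotoxicity, read by MTT assay, with a stated time of 48 h; on this read-out higher numbers stand for weaker inhibition and lower numbers for stronger inhibition:
- Compound 1 `CCOC(=O)C1=C(C)NC(=S)NC1c1cccc(OCCCOc2cccc(C3NC(=S)NC(C)=C3C(=O)OCC)c2)c1`: 144 ug/mL
- Compound 2 `COC(=O)[C@@H]1CCCN1C(=O)C1=C(C)NC(=S)NC1c1cccc(OC/C=C\COc2cccc(C3NC(=S)NC(C)=C3C(=O)N3CCC[C@H]3C(=O)OC)c2)c1`: 180 ug/mL

Among the compounds with values here, only these two compounds have numbers so far. In this assay, compound 2 gives 180 ug/mL, and this lies within the usual scatter of the figure for compound 1, 144 ug/mL. Neither compound can therefore be ranked over the other on these data.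

The next compound to be tested is compound 3 `COC(=O)[C@@H]1CCCN1C(=O)C1=C(C)NC(=S)NC1c1cccc(OC/C=C/COc2cccc(C3NC(=S)NC(C)=C3C(=O)N3CCC[C@H]3C(=O)OC)c2)c1`. Its difference from compound 2 is a single one: the two compounds have the same atoms and bonds; at least one stereo element is drawn with a configuration in one of them and without one in the other: 1 of 5 stereo elements differ; a double bond is drawn Z in compound 2 and E in compound 3. The two compounds have the same atoms and bonds, and a double bond is drawn Z in compound 2 and E in compound 3.

Within the data shown here, no measured pair yet shows what such a change does to the read-out, so the expectation has little to rest on. Among the measured compounds shown here, the only guide is the level of the two known values, which sit within scatter of each other. No step beyond the scatter is expected in this assay, in either direction. The expected 1.1-fold lower number from compound 2 to compound 3 (0.04 log units; within the scatter) is small. For compound 3 the estimated value is 165 ug/mL, with a range from 90 ug/mL to 280 ug/mL.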

Compound 3, half-maximal inhibitory concentration: 127 ug/mL
Estimate against measurement, compound 3: 1.3-fold (0.11 log units) above, and the stated range covers the measured number.
By their numbers in this assay, from the lowest: compounds 3, 1 and 2 (each within the scatter of the next).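

Within the data shown here, this pair is the first to differ in one place only, so the geometry of the double bond can be read on its own for the first time: in this assay, the change from Z to E gives a 1.4-fold lower number from compound 2 to compound 3 (0.15 log units; within the scatter). At this double bond, the drawn geometry therefore does not separate the two compounds on this read-out, and neither can be ranked over the other. One point about the structures qualifies this reading of the pair: the fact that one of compounds 2 and 3 is drawn with a defined configuration and the other without, at the place where they differ

Among these compounds, compound 1 differs from compound 2 and compound 3 in more than one place, so no step to it can be read, and the separate parts played by the saturated chain and the ester groups stay unresolved. As far as these compounds go, it also remains open whether a triple bond in the chain, a longer chain, or a carboxylic acid in place of the methyl ester would move the number in this assay beyond the scatter.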